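The source may report more compounds than this note shows. Statements on the series, on what has been measured and on what is new or still open speak of the compounds shown alone.

Measured so far:
compound 1 `Nc1ccccc1NC(=O)c1ccc(CSC(=S)N2CCN(C3CCCCC3)CC2)cc1` gives 89.9%
compound 2 `CC1CCCCN1C(=S)SCc1ccc(C(=O)Nc2ccccc2N)cc1` gives 85.2%
compound 3 `CCN(Cc1ccncc1)C(=S)SCc1ccc(C(=O)Nc2ccccc2N)cc1` gives 86.2%

These values come from a functional assay on A-375 cells (Homo sapiens) for antiproliferative activity, read by CCK-8 assay, with a stated time of 72 h, tested at 8 uM; a lower number here means a weaker effect, a higher number a stronger effect of the compound at the concentration tested. Compound 3 stands second highest of the three numbers, with compound 2 nearest and compound 1 furthest, both gaps within the scatter, so no order among them can be claimed. Compound 4 `CC1CCN(C(=S)SCc2ccc(C(=O)Nc3ccccc3N)cc2)CC1` differs from compound 3 in one place: 4-methylpiperidin-1-yl in place of ethyl((pyridin-4-yl)methyl)amino on a thiocarbonyl carbon. Within the data shown here, the only measured step at this spot, a number 1 percentage points higher from compound 2 to compound 3 (within the scatter), also exchanged the amine on the thiocarbonyl carbon and stayed within the scatter. For compound 4, which again alters only this amine, a step of a number 0.2 percentage points lower from compound 3 to compound 4 (within the scatter) of no size beyond the scatter is expected in this assay. Compound 4 is therefore estimated at 86%, with a range from 76% to 94%.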

Compound 4, a percentage reported as inhibition, at one concentration (the size of the read-out at that concentration, not a potency): 87.4%
The estimate for compound 4 lay 1.4 percentage points below the measured number; low and high end bracket the measured number.
By their numbers in this assay, from the lowest: compounds 2, 3, 4 and 1 (each within the scatter of the next).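

In this assay, exchanging ethyl((pyridin-4-yl)methyl)amino for 4-methylpiperidin-1-yl removes the aromatic ring from this amine and gives a number 1.2 percentage points higher from compound 3 to compound 4 (within the scatter) on the thiocarbonyl carbon. Moving the methyl group from the 2-methylpiperidin-1-yl arrangement to 4-methylpiperidin-1-yl gives a number 2.2 percentage points higher from compound 2 to compound 4 (within the scatter), so neither change moves the read-out beyond the scatter. No measured evidence is available to explain this result.

On these data alone, it remains open whether a carboxylic acid on the piperidine ring or a longer chain in place of the methyl group would change the number. A reading at one concentration also leaves the potency of these compounds unknown.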